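Dropping the Cyclopropyl from the Benzimidazole Amide

A few compounds are considered here, and "the series" means these few. Any claim that something is new, unique, unknown or untested is made for them only; others in the source may bear on it.

Compound 2 `CS(=O)(=O)N1CCN(CC(O)CN2CCC(CNC(=O)c3cccc4[nH]c(C5CC5)nc34)CC2)CC1` was tested in a functional assay for agonist activity at 5-hydroxytryptamine receptor 4 (Homo sapiens), read by cAMP accumulation (a higher number here means a larger maximal response, a lower number a smaller maximal response), where compound 2 reached 64%. Compound 1 `CC(=O)N(C)CC(O)CN1CCC(CNC(=O)c2cccc3[nH]c(C(C)C)nc23)CC1` gave 64%, level with compound 2 within the scatter, and these two stand together as the highest of the three measured values. Compound 3 `CS(=O)(=O)N1CCN(CC(O)CN2CCC(NC(=O)c3cccc4[nH]cnc34)CC2)CC1` gave only 7%, a result far below compound 2 and beyond the scatter. Compound 4 `CS(=O)(=O)N1CCN(CC(O)CN2CCC(CNC(=O)c3cccc4[nH]cnc34)CC2)CC1` differs from compound 2 in one place: hydrogen in place of cyclopropyl on an aromatic carbon. Compound 3 also carries hydrogen there, though its linker to the amide differs as well, so its value of 7% only hints at what this change does. A drop in maximal response is expected, with an estimated step of a number 34 percentage points lower from compound 2 to compound 4 (beyond the scatter). Compound 4 is estimated to reach 30%, ranging from 5% to 60%.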

Compound 4, intrinsic activity: the largest response reached, in percent of the reference agonist's: 6%
Compound 4: the middle estimate sits 24 percentage points above what was measured; the measured number falls inside the stated range.
By their numbers in this assay, from the lowest: compounds 4 and 3 (each within the scatter of the next); then compounds 1 and 2 (each within the scatter of the next).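

Replacing cyclopropyl with hydrogen on the aromatic carbon between two ring nitrogen atoms gives a number 58 percentage points lower from compound 2 to compound 4 (beyond the scatter) in this assay. Compound 3 changed its linker as well, whereas compound 4 keeps the rest of compound 2, so this one change is enough to leave little response. No available data explain the loss. Going by these compounds, what remains open is how a methyl, an ethyl or an amine at this carbon would fare, and so whether response rises gradually with the group or needs a cyclopropyl specifically.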